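This account rests on a few compounds, and the source may have more. Where it says the series, first, only, none or still open, it means among the compounds named here.

Three compounds have been measured in a physicochemical assay for solubility; a lower number here means a less soluble compound, a higher number a more soluble compound:

- compound 1 `Cc1nc(C)c(C(=O)Oc2ccc(-c3cc(=O)c4c(O)c(O)c(O)cc4o3)cc2)nc1C`: 12.1 ug/mL
- compound 2 `Cc1nc(C)c(C(=O)N[C@@H](C(=O)Oc2ccc(-c3cc(=O)c4c(O)c(O)c(O)cc4o3)cc2)C(C)C)nc1C`: 240 ug/mL
- compound 3 `Cc1nc(C)c(COC(=O)N[C@@H](C(=O)Oc2ccc(-c3cc(=O)c4c(O)c(O)c(O)cc4o3)cc2)C(C)C)nc1C`: 252 ug/mL

Compound 3 shares the top of this small set with compound 2, and the step between them is a 1.1-fold higher number from compound 2 to compound 3 (0.02 log units; within the scatter). Compound 1 stands well apart, with a far lower number than either of them.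

The next compound is compound 4 `CC[C@H](C)[C@@H](NC(=O)OCc1nc(C)c(C)nc1C)C(=O)Oc1ccc(-c2cc(=O)c3c(O)c(O)c(O)cc3o2)cc1`, which differs from compound 3 in one place: methyl in place of hydrogen on a saturated chain carbon, three bonds along the chain from an amide-type nitrogen and a carbonyl carbon. Put another way, isopropyl becomes sec-butyl, with methyl in place of hydrogen on a saturated chain carbon, three bonds along the chain from an amide-type nitrogen and a carbonyl carbon.

Little of the data bears directly on this change. Going by the values given here, the only measured single-place step, a 1.1-fold higher number from compound 2 to compound 3 (0.02 log units; within the scatter), concerns a different part of the molecule, on a carbonyl carbon. It does show that this assay stayed flat across that edit. Among the compounds with values here, no measured pair tests the isopropyl itself, and compound 1, which lacks it, differs from the others in more than one way. No step beyond the scatter is therefore expected, and any drift is taken as slightly downward, an estimated 1.3-fold lower number from compound 3 to compound 4 (0.10 log units; within the scatter).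

For compound 4 the expected value is 200 ug/mL, with an estimated range from 90 ug/mL to 400 ug/mL.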

Compound 4, solubility: 234 ug/mL
Beside the measured number, compound 4's estimate is 1.2-fold (0.07 log units) below it, and the stated range covers the measured number.
By their numbers in this assay, from the lowest: compound 1; then compounds 4, 2 and 3 (each within the scatter of the next).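

In this assay, going by these compounds alone, the change from isopropyl to sec-butyl gives a 1.1-fold lower number from compound 3 to compound 4 (0.03 log units; within the scatter), the first measured test of this side chain, which the earlier compounds left untested. At this saturated chain carbon, three bonds along the chain from an amide-type nitrogen and a carbonyl carbon, a methyl in place of hydrogen therefore leaves the read-out within the scatter for this pair. Together with a 1.1-fold higher number from compound 2 to compound 3 (0.02 log units; within the scatter), which concerns a different place on a carbonyl carbon, this gives two single-place edits among compounds 2, 3 and 4, neither of which moves the number beyond the scatter, and no information bearing on the reason for this accompanies the result.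

On these data alone, one methyl is a small edit, so it remains open whether this position would stay as flat with a longer chain, a phenyl ring, an amine or a carboxylic acid in place of sec-butyl. Within the data shown here, the result also leaves open how the opposite configuration at the new branching carbon would read in this assay, and no single-place step yet connects compound 1 to the other compounds.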